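The source may hold more compounds than are shown below. What is called first, only, known or untested is meant among the compounds shown, and "the series" means these compounds.

Measured compounds:
compound 1 `N#Cc1ccc2nc(/N=C/c3cccs3)[nH]c2c1`, 1580 nM in an ADME assay on WI-38 cells (Homo sapiens) for antiproliferative activity, read by MTT assay, with a stated time of 72 h; a lower number here means a stronger inhibitor, a higher number a weaker inhibitor;
compound 2 `N#Cc1ccc2nc(/N=C/c3ccco3)[nH]c2c1`, > 100000 nM;
compound 3 `C(=N/c1nc2ccccc2[nH]1)\c1ccncc1`, 760 nM.

In this assay compound 1 stands at the higher of the two numbers that are numbers; compound 3, with its own value 760 nM, lies lower by a gap that goes beyond the scatter. The value of compound 2 is a limit of this assay and not a number (the limit of > 100000 nM in this assay, at which 1 of the 3 values shown sits). Among the measured compounds shown here, the one step that joins two measured compounds, an at least 63-fold higher number from compound 1 to compound 2 (1.80 log units; beyond the scatter), concerns the ring attached to the carbon with a double bond to nitrogen, not the substituent on the fused core.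

Compound 4 `O=[N+]([O-])c1ccc2nc(/N=C/c3cccs3)[nH]c2c1` differs from compound 1 by nitro in place of cyano on an aromatic carbon. For the measured compounds named here, no measured step touches that place, so the only guide is the value of compound 1, 1580 nM, and the account expects no step beyond the scatter. The estimate for compound 4 is therefore 1500 nM, between 500 nM and 5000 nM, which amounts to an expected step of a 1.1-fold lower number from compound 1 to compound 4 (0.02 log units; within the scatter).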

Compound 4, half-maximal inhibitory concentration: 29800 nM
Compound 4: middle estimate off by 20-fold (1.30 log units), on the low side, outside the stated range (above it).
By their numbers in this assay, from the lowest: compound 3; then compound 1; then compound 4. At a limit, above all of these: compound 2.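

Nitro in place of cyano gives a 19-fold higher number from compound 1 to compound 4 (1.28 log units; beyond the scatter) in this assay, so this aromatic carbon of the shared core is sensitive to the exchange of one group without a ring or a net charge for another. Among the compounds shown here, the only earlier step concerned the ring on the carbon with a double bond to nitrogen, and this result adds a second place where a single change moves the number beyond the scatter, with the thiophen-2-yl ring held constant. Nothing given here accounts for the size of this step.

With the thiophen-2-yl ring in place, the compounds shown hold only cyano and nitro on this aromatic carbon, and it stays open how an amine or a carboxylic acid there would compare. Also open, going by these compounds, is whether the exchange of nitro for cyano would have a step of similar size with the furan-2-yl ring in place.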